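The compounds below may be only part of what the source reports. "The series", "measured", "known", "first", "only" and "open" are said of these compounds alone.

Measured in a functional assay on MCF7 cells (Homo sapiens) for antiproliferative activity, read by MTT assay, with a stated time of 24 h; on this read-out lower numbers stand for stronger inhibition and higher numbers for weaker inhibition:
- Compound 1 `CCN(CC)CCNC(=O)C1CC=C(C(CC)(CC)c2ccc(C#CC(C)(C)O)c(C)c2)N1CC`: 1490 nM
- Compound 2 `CCN(CC)CCNC(=O)C1CC=C(C(CC)(CC)c2ccc(C#CC(C)(O)CC)c(C)c2)N1CC`: 600 nM
- Compound 3 `CCCC(O)(C#Cc1ccc(C(CC)(CC)C2=CCC(C(=O)NCCN(CC)CC)N2CC)cc1C)CCC`: 1360 nM

Compound 3 sits at the upper end of these numbers: there is a 1.1-fold lower number from compound 1 to compound 3 (0.04 log units; within the scatter), which is no real difference, and a 2.3-fold higher number from compound 2 to compound 3 (0.36 log units; beyond the scatter). Compound 4 `CCN(CC)CCNC(=O)C1CC=C(C(CC)(CC)c2ccc(C#CC(O)C3CCCC3)c(C)c2)N1CC` is not yet measured. It differs in one place: a group of 7 heavy atoms (6 carbon, 1 oxygen; one five-membered non-aromatic ring of carbon only) in place of a group of 8 heavy atoms (7 carbon, 1 oxygen; no ring), on a triple-bonded carbon. The measured changes to this group were small, the largest being a 2.5-fold lower number from compound 1 to compound 2 (0.40 log units; beyond the scatter). Going by the values given here, none of the measured compounds has a ring in this group, so the data offer no direct guide. No step beyond the scatter is therefore expected in this assay, and the estimated change is a 1.4-fold lower number from compound 3 to compound 4 (0.13 log units; within the scatter). For compound 4 the expected value is 1000 nM, with an estimated range of 400 nM to 2500 nM.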

Compound 4, half-maximal inhibitory concentration: 1580 nM
The estimate for compound 4 lay 1.6-fold (0.20 log units) below the measured number; measured number inside the range.
By their numbers in this assay, from the lowest: compound 2; then compounds 3, 1 and 4 (each within the scatter of the next).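

In this assay the only ring at this position, cyclopentyl(hydroxy)methyl on the triple-bonded carbon, shows a 1.2-fold higher number from compound 3 to compound 4 (0.07 log units; within the scatter) and a 1.1-fold higher number from compound 1 to compound 4 (0.03 log units; within the scatter) so it cannot be told apart from those two open-chain groups. The 1-hydroxy-1-methylpropyl group stays apart, with a 2.6-fold higher number from compound 2 to compound 4 (0.42 log units; beyond the scatter) and this ring does not reach the lower number of compound 2. No measured evidence explains this gap. Still open, going by these compounds, is whether an amine in place of the hydroxy group would change the number, and whether a cyclohexyl or phenyl ring would behave like cyclopentyl.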